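Aryl sulfonate anilides: halogen for isopropyl on the phenol ring

The compounds below may be only part of what the source reports. "The series", "measured", "known", "first", "only" and "open" are said of these compounds alone.

Measured so far:
compound 1 `CCCC(=O)Nc1cccc(S(=O)(=O)Oc2ccccc2C(C)C)c1` — 13000 nM
compound 2 `CC(C)c1ccccc1OS(=O)(=O)c1cccc(NC(=O)CCCl)c1` — 11000 nM
compound 3 `CC(=O)Nc1ccc(S(=O)(=O)Oc2ccccc2C(C)C)cc1` — 23000 nM

In a functional assay on HT-29 cells (Homo sapiens) for antiproliferative activity, read by sulforhodamine B assay, with a stated time of 48 h (a higher number here means a weaker inhibitor, a lower number a stronger inhibitor), compound 3 gives the highest of the three numbers. Its nearest neighbour is compound 1, whose value 13000 nM lies within the scatter of it; compound 2, with 11000 nM, sits beyond the scatter on the lower side. Among the measured compounds shown here, the only single-point step measured so far, a 1.2-fold lower number from compound 1 to compound 2 (0.07 log units; within the scatter), concerns the acyl chain on the anilide and leaves the phenol ring untouched.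

Compound 4 `CC(=O)Nc1ccc(S(=O)(=O)Oc2ccccc2I)cc1` is compound 3 with the change (iodo in place of isopropyl on an aromatic carbon). For the measured compounds named here, no measured step in this assay touches the group on the phenol ring next to the sulfonate oxygen: the step from compound 1 to compound 2 changes a different part of the molecule and gives no guidance here. With nothing on the phenol-ring substituent to go on, the working expectation is that the number stays close to that of compound 3, with a step of a 1.2-fold lower number from compound 3 to compound 4 (0.06 log units; within the scatter) that does not clearly exceed the scatter in either direction. Compound 4 is therefore estimated at 20000 nM in this assay, with a range from 7000 nM to 60000 nM reflecting the absence of any relevant precedent.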

Compound 4, half-maximal inhibitory concentration: 23000 nM
The estimate for compound 4 lay 1.2-fold (0.06 log units) below the measured number, within the range that was stated.
By their numbers in this assay, from the lowest: compounds 2, 1, 3 and 4 (each within the scatter of the next, the first and the last beyond it).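

In this assay, among the compounds shown here, the position on an aromatic carbon ortho to a large group now has a measured step of its own: iodo in place of isopropyl gives no change at the digits printed from compound 3 to compound 4 (within the scatter) and is the first reading on the phenol ring, since the earlier step concerned only the acyl chain. On the core of compound 3, this read-out therefore does not separate the two groups, even though 3 heavy atoms of carbon leave and 1 iodine atom enters. No separate measurement bears on this result, so the pair gives a reading and no explanation.

From the compounds shown here alone, one pair fixes nothing beyond compound 3 and compound 4, so it remains open whether the same swap would read the same on the core of compound 1 or of compound 2. Also open, going by these compounds, is how an amine, a carboxylic acid, a methoxy group or a longer chain would read at this position, and whether a phenol ring with only hydrogen there would stand apart from both compound 3 and compound 4.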